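A few compounds are considered here, and "the series" means these few. Any claim that something is new, unique, unknown or untested is made for them only; others in the source may bear on it.

Measured compounds:
- Compound 1 `CCC(CC)CNc1c(C(N)=O)cnc2ccc(C#N)cc12`: 820 nM
- Compound 2 `C[C@@H](Nc1c(C(N)=O)cnc2ccc(C#N)cc12)c1ccc(Cl)cc1`: 14400 nM
- Compound 3 `CCC(CC)CNc1c(C(N)=O)cnc2ccc(-c3cccnc3)cc12`: 73 nM

Of the three compounds measured in an assay on HT-29 cells for inhibition of Serine-protein kinase ATM (Homo sapiens), read by fluorescence, with a stated time of 1 h (on this read-out lower numbers stand for stronger inhibition and higher numbers for weaker inhibition), compound 3 gives the lowest number, 73 nM; compound 1 sits nearest, and compound 2 furthest away with 14400 nM. Among the compounds with values here, the only step measured in one place, an 11-fold lower number from compound 1 to compound 3 (1.05 log units; beyond the scatter), concerns the group on the fused ring, not the side chain.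

Compound 4 `NC(=O)c1cnc2ccc(-c3cccnc3)cc2c1SC1CCCC1` differs from compound 3 at the other end of the shared core: cyclopentylsulfanyl in place of (2-ethylbutyl)amino on an aromatic carbon. Within the data shown here, no measured step bears directly on this change; the side chain was altered only between compound 1 and compound 2, which were not compared as a single step, and their two values show a much higher number for compound 2. With the amine replaced by a sulfur-linked ring and a hydrogen-bond donor lost, a weakening is expected, of uncertain size. Compound 4 is therefore estimated at 400 nM, within 80 nM to 2000 nM, an expected step of a 5.5-fold higher number from compound 3 to compound 4 (0.74 log units; beyond the scatter).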

Compound 4, half-maximal inhibitory concentration: 9700 nM
For compound 4 the middle estimate is 24-fold (1.38 log units) below the measured one; measured number above the stated range.
By their numbers in this assay, from the lowest: compound 3; then compound 1; then compounds 4 and 2 (each within the scatter of the next).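

In this assay, replacing (2-ethylbutyl)amino with cyclopentylsulfanyl gives a 130-fold higher number from compound 3 to compound 4 (2.12 log units; beyond the scatter), the first single-place step measured at this position, on the aromatic carbon opposite the ring nitrogen. It shows that inhibition in this series can depend heavily on the group here, even with the pyridin-3-yl group of compound 3 kept in place. The swap changes the linking atom, replaces an open chain with a five-membered ring and removes a hydrogen-bond donor all at once, and no measurement here explains the weakening.

The compounds shown leave open whether the sulfur link or the ring matters more. Cyclopentylamino, which keeps the ring on a nitrogen link, and (2-ethylbutyl)sulfanyl, which keeps the chain on a sulfur link, would help separate the two.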